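Replacing nitro with methoxycarbonyl on compound 1

This account rests on a few compounds, and the source may have more. Where it says the series, first, only, none or still open, it means among the compounds named here.

In an ADME assay for permeability, using PAMPA, at pH 7.4 (on this read-out higher numbers stand for higher permeability and lower numbers for lower permeability), compound 1 `Cc1cc(NC(=O)Nc2cccc([N+](=O)[O-])c2)c2ccccc2n1` gives 42 10^-6 cm/s and lies within the scatter of compound 3 `Cc1cc(NC(=O)Nc2cnc3ccccc3c2)c2ccccc2n1` with 46 10^-6 cm/s on the same scale. Compound 2 `COC(=O)c1ccc(NC(=O)Nc2cc(C)nc3ccccc23)cc1` has the highest number of the three with 448 10^-6 cm/s and already carries a methoxycarbonyl. Compound 4 `COC(=O)c1cccc(NC(=O)Nc2cc(C)nc3ccccc23)c1` has methoxycarbonyl in place of nitro on an aromatic carbon, meta to a large group, relative to compound 1 (methoxycarbonyl in place of nitro on an aromatic carbon). Among the compounds with values here, no measured pair differs in one place, so the expectation rests on compound 2 and its 448 10^-6 cm/s alone. In this assay the expected change is upward and beyond the scatter, an estimated 6.7-fold higher number from compound 1 to compound 4 (0.82 log units; beyond the scatter) for this replacement. Compound 4 is expected at 280 10^-6 cm/s with an estimated range from 100 10^-6 cm/s to 650 10^-6 cm/s as a working figure.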

Compound 4, apparent permeability: 746 10^-6 cm/s
The estimate for compound 4 lay 2.7-fold (0.43 log units) below the measured number, outside the stated range (above it).
By their numbers in this assay, from the lowest: compounds 1 and 3 (each within the scatter of the next); then compounds 2 and 4 (each within the scatter of the next).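

In this assay, methoxycarbonyl in place of nitro on an aromatic carbon, meta to a large group, gives an 18-fold higher number from compound 1 to compound 4 (1.25 log units; beyond the scatter). Within the data shown here, this is the first one-place reading of this change, and it is large. Compound 4 lies within the scatter of compound 2, so two methoxycarbonyl compounds now share the upper level, and no supporting data bear on the reason for the step. On these data alone, whether a carboxylic acid, a nitrile or an amine on the same aromatic carbon would hold this level remains open. As far as these compounds go, whether the step carries over to another core is also open.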